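Acetamido for cyano on a second core

This account rests on a few compounds, and the source may have more. Where it says the series, first, only, none or still open, it means among the compounds named here.

Measured compounds:
compound 1 `N#Cc1ccc(S(=O)(=O)N2C/C(=C\c3cccnc3)C(=O)/C(=C/c3ccccc3F)C2)cc1`, compound 2 `CC(=O)Nc1ccc(S(=O)(=O)N2C/C(=C\c3cccnc3)C(=O)/C(=C/c3ccccc3F)C2)cc1`, compound 3 `N#Cc1ccc(S(=O)(=O)N2C/C(=C\c3ccncc3)C(=O)/C(=C/c3ccccc3C(F)(F)F)C2)cc1`

In a functional assay on QGY-7703 cells (Homo sapiens) for cytotoxicity, read by MTT assay, with a stated time of 24 h (on this read-out lower numbers stand for stronger inhibition and higher numbers for weaker inhibition), compound 1 gives 15800 nM, compound 2 gives 9640 nM and compound 3 gives 6290 nM. Compound 2 differs from compound 1 by acetamido in place of cyano on an aromatic carbon, and this change gave a 1.6-fold lower number from compound 1 to compound 2 (0.21 log units; within the scatter). Compound 4 `CC(=O)Nc1ccc(S(=O)(=O)N2C/C(=C\c3ccncc3)C(=O)/C(=C/c3ccccc3C(F)(F)F)C2)cc1` is not yet measured; it differs from compound 3 by acetamido in place of cyano on an aromatic carbon, the same change made on a different core, and the difference between the two cores is not broken down here. Among the measured compounds shown here, the only measured example of this change moved the number little, so the step from compound 3 to compound 4 in this assay is expected to be of similar size, a 1.6-fold lower number from compound 3 to compound 4 (0.21 log units; within the scatter), resting on compound 2 giving 9640 nM after the same change. Compound 4 is therefore estimated at 3900 nM, expected to lie between 1500 nM and 10000 nM.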

Compound 4, half-maximal inhibitory concentration: 5560 nM
Compound 4: middle estimate off by 1.4-fold (0.15 log units), on the low side; measured number inside the range.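

In this assay replacing cyano with acetamido on the second core gave a 1.1-fold lower number from compound 3 to compound 4 (0.05 log units; within the scatter) and so left the number about where it was. Set side by side, the two examples of this change do not differ: the same change on two cores in this assay, a 1.6-fold lower number (0.21 log units; within the scatter) from compound 1 to compound 2 and a 1.1-fold lower number (0.05 log units; within the scatter) from compound 3 to compound 4, 1.4-fold (0.16 log units) apart, within the scatter of two such steps. This shows that the change had a similarly small effect on these two cores in this assay, but it does not show that the same would hold on any other core, and neither step favours one group over the other.

Still open, going by these compounds, is whether a different group on the same aromatic carbon, such as an amine or a carboxylic acid, would shift the number more. Also open, on these data alone, is how each difference between the two cores contributes on its own.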